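The source may report more compounds than this note shows. Statements on the series, on what has been measured and on what is new or still open speak of the compounds shown alone.

Measured so far:
- compound 1, `CCCCCCCCc1ccc(OCC(=O)Cn2nnc(-c3cccnc3)n2)cc1`, 23 nM
- compound 2, `CCCCCCCCc1ccc(OCC(=O)Cn2nnnc2-c2ccccc2)cc1`, 71 nM

In an assay on microsomes from brain for inhibition of Fatty-acid amide hydrolase 1 (Rattus norvegicus), read by fluorescence and HPLC, with a stated time of 60 min (on this read-out higher numbers stand for weaker inhibition and lower numbers for stronger inhibition), compound 1 gives 23 nM, and compound 2 gives 71 nM. Of the two numbers, compound 2 holds the higher one, and the gap to compound 1 lies beyond the usual scatter, so compound 2 is the weaker inhibitor of the pair on this read-out. Among the measured compounds shown here, no single-change step between the measured compounds is available, so nothing directly tells how this core responds to a change on the five-membered ring.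

Compound 3, `CCCCCCCCc1ccc(OCC(=O)Cn2nnnc2C(=O)OCC)cc1`, has not yet been measured. It differs from compound 2 by one change: ethoxycarbonyl in place of phenyl on an aromatic carbon. For the measured compounds named here, with no measured step of this kind to draw on, the expectation rests on compound 2 alone. The account expects compound 3 to sit somewhat weaker than compound 2, with an estimated step of a 2.1-fold higher number from compound 2 to compound 3 (0.32 log units; beyond the scatter) that is small and only at the edge of the scatter. For compound 3 in this assay the estimate is 150 nM, with a likely range from 40 nM to 600 nM.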

Compound 3, half-maximal inhibitory concentration: 940 nM
For compound 3 the middle estimate is 6.3-fold (0.80 log units) below the measured one; measured number above the stated range.
By their numbers in this assay, from the lowest: compound 1; then compound 2; then compound 3.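

Replacing phenyl with ethoxycarbonyl on the aromatic carbon of the five-membered aromatic ring with 4 nitrogen gives a 13-fold higher number from compound 2 to compound 3 (1.12 log units; beyond the scatter) in this assay, the first single-change step available on this core and a large one. It shows that inhibition on this read-out depends strongly on the group at this place, even though the group that leaves and the group that enters are close in heavy-atom count, so that count alone does not account for the result. No measured property or other outside information bears on why the step is this large, and it stands here as an observation only.

The compounds shown leave open whether the step follows from the loss of the six-membered aromatic ring or from the arrival of ethoxycarbonyl, as this place offers only this one comparison. A benzyl group, a carboxylic acid or a plain ethyl group on the same carbon would help to separate these two readings, and none of them is among the compounds shown.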